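This account rests on a few compounds, and the source may have more. Where it says the series, first, only, none or still open, it means among the compounds named here.

Compound 1 `Cc1ccc(Cn2cc(COc3ccc4c(=O)ccoc4c3)nn2)cc1` in a functional assay on SGC-7901 cells (Homo sapiens) for cytotoxicity, read by MTT assay, with a stated time of 48 h; on this read-out higher numbers stand for weaker inhibition and lower numbers for stronger inhibition: > 100000 nM, a limit of the assay.
Compound 2 `O=c1ccoc2cc(OCc3cn(Cc4ccc(Cl)cc4)nn3)ccc12` in this assay: > 100000 nM, likewise a limit.
Compound 3 `Cc1ccccc1Cn1cc(COc2ccc3c(=O)ccoc3c2)nn1`: not yet measured.

Compound 2 thus sits at the limit, with no number below it. For the measured compounds named here, the only measured step, a step that the two limits leave unreadable from compound 1 to compound 2, is unreadable, since the limit of > 100000 nM in this assay, at which 2 of the 2 values shown sit, covers both of its ends. Compound 3 differs from compound 2 by 2-methylphenyl in place of 4-chlorophenyl on a saturated chain carbon bound to an aromatic nitrogen. No readable step bears on this change, so no direction beyond the scatter is expected. Compound 3 is therefore expected to give 150000 nM (range 50000 nM to 500000 nM), most likely again reported only as a limit. The expected step that the limit leaves unreadable from compound 2 to compound 3 is one of no change.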

Compound 3, half-maximal inhibitory concentration: > 100000 nM
Compound 3 gave a limit, no number (the forecaster's own chance of this, stated with the estimate: 85%); the middle value lies beyond the limit too.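

For the compounds shown here, no step among compound 1, compound 2 and compound 3 can be read in this assay, because each value is only a limit: the limit of > 100000 nM in this assay, at which 3 of the 3 values shown sit. The compounds shown leave open whether any group at this place would give a measurable value.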